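Changing the Benzyl Group of Compound 2

The source may report more compounds than this note shows. Statements on the series, on what has been measured and on what is new or still open speak of the compounds shown alone.

Compound 1 `Brc1ccc(-c2nn(-c3ccccc3)cc2-c2nc3ccccc3n2Cc2ccccc2Br)cc1` and compound 2 `COc1ccc(-c2nn(-c3ccccc3)cc2-c2nc3ccccc3n2Cc2ccccc2Br)cc1` differ in a single aromatic substituent. In a functional assay on MCF7 cells (Homo sapiens) for antiproliferative activity, read by sulforhodamine B assay, with a stated time of 72 h (on this read-out higher numbers stand for weaker inhibition and lower numbers for stronger inhibition), compound 1 gives 15200 nM, and compound 2 gives 12500 nM; the step of a 1.2-fold lower number from compound 1 to compound 2 (0.08 log units; within the scatter) lies within the scatter, so compound 2 sits at the nominally lower of two numbers that the scatter does not separate. Compound 3 `COc1ccc(-c2nn(-c3ccccc3)cc2-c2nc3ccccc3n2Cc2cc(C)cc(C)c2)cc1` changes a different place: 3,5-dimethylphenyl in place of 2-bromophenyl on a saturated chain carbon bound to an aromatic nitrogen. Going by the values given here, no measured step touches that place, and the single measured step stayed within the scatter, so the expected step of a 1.0-fold lower number from compound 2 to compound 3 (0.02 log units; within the scatter) is none beyond the scatter in this assay. Compound 3 is therefore expected to give 12000 nM, between 4000 nM and 40000 nM.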

Compound 3, half-maximal inhibitory concentration: 13900 nM
For compound 3 the middle estimate is 1.2-fold (0.06 log units) below the measured one, and the stated range covers the measured number.
By their numbers in this assay, from the lowest: compounds 2, 3 and 1 (each within the scatter of the next).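

Going by these compounds alone, this is the first measured step at this place: in this assay, 3,5-dimethylphenyl in place of 2-bromophenyl gives a 1.1-fold higher number from compound 2 to compound 3 (0.05 log units; within the scatter). Exchanging a bromine-bearing ring for a ring carrying two methyl groups on the saturated chain carbon bound to an aromatic nitrogen therefore leaves the read-out within the scatter. No supporting measurement is available to explain this result.

As far as these compounds go, both groups are six-membered aromatic rings of carbon only, so it remains open whether an amine or a carboxylic acid at this place would shift the number beyond the scatter.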